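Moving a nitrile on a biaryl tail: expected cytotoxicity

A few compounds are considered here, and "the series" means these few. Any claim that something is new, unique, unknown or untested is made for them only; others in the source may bear on it.

Of the compounds shown here, three that share one core have been measured for how strongly they harm cultured cells. Compound 1 `Cc1cc(-c2cccc(C#N)c2)cc(C)c1Oc1cc(N)nc(Nc2ccc(C#N)cc2)n1` carries a 3-cyanophenyl group and two methyl groups on its central ring. In a toxicity assay on MT4 cells (Homo sapiens) for cytotoxicity, read by MTT assay (on this read-out lower numbers stand for higher toxicity in this test and higher numbers for lower toxicity in this test), compound 1 gives 20200 nM. Compound 2 `Cc1cc(-c2ccc(C#N)cc2)cc(C)c1Oc1cc(N)nc(Nc2ccc(C#N)cc2)n1` differs from compound 1 in one place: 4-cyanophenyl in place of 3-cyanophenyl on an aromatic carbon. In this assay compound 2 gives 18100 nM, and the step is a 1.1-fold lower number from compound 1 to compound 2 (0.05 log units; within the scatter). Compound 3 `Cc1cc(-c2cccc(C#N)c2)ccc1Oc1cc(N)nc(Nc2ccc(C#N)cc2)n1` differs from compound 1 in another place: hydrogen in place of methyl on an aromatic carbon. In this assay compound 3 gives 27400 nM, with a 1.4-fold higher number from compound 1 to compound 3 (0.13 log units; within the scatter). All three numbers therefore sit close together, and none can be singled out.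

Compound 4 `Cc1cc(-c2ccc(C#N)cc2)ccc1Oc1cc(N)nc(Nc2ccc(C#N)cc2)n1` has not yet been measured. It differs from compound 3 as follows: 4-cyanophenyl in place of 3-cyanophenyl on an aromatic carbon. This is the same kind of change as from compound 1 to compound 2, not the same change, since the surroundings of the place differ: in the first pair the carbon is meta to two methyl groups, while in the second it is meta to a methyl group. Since the earlier step was a 1.1-fold lower number from compound 1 to compound 2 (0.05 log units; within the scatter), the step from compound 3 to compound 4 is expected to be small as well, about a 1.1-fold lower number from compound 3 to compound 4 (0.04 log units; within the scatter). Compound 4 is thus estimated to give 25000 nM in this assay, with a likely range from 13000 nM to 50000 nM, resting on the value of compound 3, 27400 nM, and on the earlier step.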

Compound 4, half-maximal cytotoxic concentration: 10400 nM
Compound 4: middle estimate off by 2.4-fold (0.38 log units), on the high side, and the stated range ends above it.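

Placing 4-cyanophenyl where 3-cyanophenyl stood on the core of compound 3 gives a 2.6-fold lower number from compound 3 to compound 4 (0.42 log units; beyond the scatter) in this assay, a modest step, while the same change on the core of compound 1 gave only a 1.1-fold lower number from compound 1 to compound 2 (0.05 log units; within the scatter), yet the two steps cannot be told apart: the same change on two cores in this assay, a 1.1-fold lower number (0.05 log units; within the scatter) from compound 1 to compound 2 and a 2.6-fold lower number (0.42 log units; beyond the scatter) from compound 3 to compound 4, 2.4-fold (0.37 log units) apart, within the scatter of two such steps. The second change, hydrogen in place of methyl, can now also be read on two cores, since it gives a 1.7-fold lower number from compound 2 to compound 4 (0.24 log units; within the scatter) alongside a 1.4-fold higher number from compound 1 to compound 3 (0.13 log units; within the scatter), and these two steps cannot be told apart either: the same change on two cores in this assay, a 1.4-fold higher number (0.13 log units; within the scatter) from compound 1 to compound 3 and a 1.7-fold lower number (0.24 log units; within the scatter) from compound 2 to compound 4, 2.4-fold (0.37 log units) apart, within the scatter of two such steps. Among these compounds, this shows that a change of nitrile position that looks modest on one core and negligible on another may still be a single effect seen through ordinary scatter, but it does not show that the change carries over unaltered, since it rests on only two pairs of compounds in one assay.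

On these data alone, what stays open is whether the same holds for other groups on the phenyl ring, such as a chlorine atom or a methoxy group in place of the nitrile. As far as these compounds go, it is equally open how an ethyl group in place of methyl on the central ring would read in this assay.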